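A few compounds are considered here, and "the series" means these few. Any claim that something is new, unique, unknown or untested is made for them only; others in the source may bear on it.

Results so far in a functional assay on MCF7 cells (Homo sapiens) for antiproliferative activity, read by MTT assay, with a stated time of 48 h; a lower number here means a stronger inhibitor, a higher number a weaker inhibitor

- Compound 1 `COC/C1=C/C[C@](C)(CCC=C(C)C)/C=C/[C@@H](OC(=O)C=C(C)C)[C@](C)(O)/C=C/C1=O` gives 4130 nM
- Compound 2 `CC(=O)O[C@]1(C)/C=C/C(=O)/C(CO)=C\C[C@](C)(CCC=C(C)C)/C=C/[C@H]1OC(=O)C=C(C)C` gives 2320 nM
- Compound 3 `C=C1/C=C/C(=O)/C(CO)=C\C[C@](C)(CCC=C(C)C)/C=C/[C@H]1OC(=O)C=C(C)C` gives 2750 nM

Compound 1 stands level with the other two. Its value lies within the usual scatter of both compound 2 and compound 3, so these three numbers cannot be ranked.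

The next compound, compound 4 `CC(C)=CCC[C@]1(C)/C=C/[C@@H](OC(=O)C=C(C)C)[C@](C)(O)/C=C/C(=O)/C(CN(C(C)C)C(C)C)=C\C1`, keeps the core of compound 1 and alters one group: diisopropylamino in place of methoxy on a saturated chain carbon bound to a double-bonded ring carbon.

Within the data shown here, no two measured compounds differ in one place only, so no measured step shows what a single swap of this kind does. Among the measured compounds shown here, the group entering here also appears in none of the measured compounds, which leaves the direction open. In this assay the expectation is therefore no step beyond the scatter. This rests on compound 2 at 2320 nM and compound 3 at 2750 nM, whose structures depart from compound 1 and whose values still stay within the scatter of it.

The estimated step is a 1.5-fold lower number from compound 1 to compound 4 (0.17 log units; within the scatter) and it remains a small one. Compound 4 is estimated at 2800 nM with an expected range from 900 nM to 8000 nM, kept wide for a group not yet tested.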

Compound 4, half-maximal inhibitory concentration: 780 nM
Estimate against measurement, compound 4: 3.6-fold (0.56 log units) above; measured number outside the range, below it.
By their numbers in this assay, from the lowest: compound 4; then compounds 2, 3 and 1 (each within the scatter of the next).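

In this assay, among these compounds, this is the first change that can be read on its own, because only this pair differs in one place: diisopropylamino in place of methoxy gives a 5.3-fold lower number from compound 1 to compound 4 (0.72 log units; beyond the scatter). This shows that the group on the saturated chain carbon bound to a double-bonded ring carbon affects the result, and that this position accepts a group with many more heavy atoms with no loss of activity; compounds 1, 2 and 3 could not show this, as their numbers could not be ranked and none of them differ from each other in one place only. No measurement shown here explains the step, so its cause remains unknown.

From the compounds shown here alone, a single swap cannot separate the effect of the nitrogen from that of the two isopropyl groups, so it remains open whether a smaller amine such as dimethylamino, or a ring amine such as piperidine, would give a similar step. Also open, going by these compounds, is whether the step would hold with the other parts of the core of compound 1 changed.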